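The source may report more compounds than this note shows. Statements on the series, on what has been measured and on what is new or still open speak of the compounds shown alone.

In an ADME assay on J774 cells (Mus musculus) for cytotoxicity, read by MTT assay, with a stated time of 48 h (on this read-out lower numbers stand for stronger inhibition and higher numbers for weaker inhibition), three compounds built on a shared core have been read. Compound 1 `O=C(CN1CCCC1)NCCNc1cc(/C=C/c2ccccc2)nc2ccccc12` gives 12500 nM, and compound 2 `O=C(CN1CCN(c2ccccc2)CC1)NCCNc1cc(/C=C/c2ccccc2)nc2ccccc12` gives 4500 nM, so compound 1 holds the higher of the two actual numbers. Compound 3 `O=C(CNc1ccc(Cl)cc1Cl)NCCNc1cc(/C=C/c2ccccc2)nc2ccccc12` is reported only as a limit, > 50000 nM.

The step followed here leads to compound 4 `CCOCC(=O)NCCCCNc1cc(/C=C/c2ccccc2)nc2ccccc12`, which has not yet been measured. The change is 2-(((ethoxymethyl)carbonyl)amino)ethyl in place of (((pyrrolidin-1-yl)methyl)carbonyl)amino on a saturated chain carbon, two bonds along the chain from a nitrogen on an aromatic ring. The five-membered non-aromatic ring leaves and no ring enters.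

Within the data shown here, three measured steps bear on this, all replacing the end group of the side chain: a 2.8-fold lower number from compound 1 to compound 2 (0.44 log units; beyond the scatter), an at least 4.0-fold higher number from compound 1 to compound 3 (0.60 log units; beyond the scatter) and an at least 11-fold higher number from compound 2 to compound 3 (1.04 log units; beyond the scatter). They run in both directions, and none of them alters the chain of compound 1 as compound 4 does, so they guide the estimate only loosely. Compound 3 is the nearer precedent, since it too has no saturated ring, and its step reads an at least 4.0-fold higher number from compound 1 to compound 3 (0.60 log units; beyond the scatter). Compound 2 keeps such a ring and went the other way. A modest rise is therefore expected in this assay. The estimate amounts to a 1.8-fold higher number from compound 1 to compound 4 (0.25 log units; within the scatter), an expected step that remains uncertain. Compound 4 is expected at 22000 nM, with an estimated range of 8000 nM to 60000 nM.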

Compound 4, half-maximal inhibitory concentration: 7200 nM
Beside the measured number, compound 4's estimate is 3.1-fold (0.49 log units) above it; the measured number lies below the stated range.
By their numbers in this assay, from the lowest: compounds 2, 4 and 1 (each within the scatter of the next, the first and the last beyond it). At a limit, above all of these: compound 3.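

In this assay, this change removes the five-membered non-aromatic ring and alters the chain, while both groups count 9 heavy atoms, and the result is a 1.7-fold lower number from compound 1 to compound 4 (0.24 log units; within the scatter). All three earlier steps replaced only the end group of the side chain and lay beyond the scatter, so this is the first step shown that alters the chain at this position, and the first to stay within the scatter. It also shows that a group with no ring can give an actual number in this assay, whereas compound 3, which has no saturated ring either, is reported only as a limit: the limit of > 50000 nM in this assay, at which 1 of the 4 values shown sits.

Because the chain and the end group change together in this single step, the compounds shown leave open how much each contributes, and whether the two effects offset each other or are both small. Also open, going by these compounds, is how the read-out would respond to a pyrrolidin-1-yl end group on the chain of compound 4, to the ethoxymethyl end group on the chain of compound 1, or to a longer chain or a terminal carboxylic acid.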